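This account rests on a few compounds, and the source may have more. Where it says the series, first, only, none or still open, it means among the compounds named here.

Measured compounds:
Compound 1, `O=C(Nc1ccc(Br)c(Cl)c1)c1cc(F)ccc1O`, gives 670 nM.
Compound 2, `N#Cc1ccc(NC(=O)c2ccc3cccnc3c2O)cc1`, gives 2320 nM.
Compound 3, `O=C(Nc1ccc(Cl)c(C(F)(F)F)c1)c1cc(F)ccc1O`, gives 540 nM.

All three values come from a functional assay on KG-1 cells (Homo sapiens) for cytotoxicity, read by luminescence and CellTiter-Glo, with a stated time of 3 days; on this read-out lower numbers stand for stronger inhibition and higher numbers for weaker inhibition. Compound 3 has the lowest of the three numbers. Its neighbour is compound 1, whose number is higher by an amount that lies within the scatter of repeated measurements, so the two cannot be placed in an order. Compound 2, which carries a different core and a nitrile on the aniline ring, stands furthest away with a number beyond the scatter.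

The step to the unmeasured compound 4, `O=C(Nc1ccc(Cl)c(Cl)c1)c1cc(F)ccc1O`, is a single change on the aniline ring of compound 3: chloro in place of trifluoromethyl on an aromatic carbon. Compounds 1 and 3 show that two different halogen-bearing patterns on this ring give numbers within the scatter of one another in this assay. Within the data shown here, no measured pair describes this exact exchange, so the expectation rests on that closeness alone. The expected step from compound 3 to compound 4 is a 1.3-fold higher number from compound 3 to compound 4 (0.11 log units; within the scatter), that is, no change beyond the scatter, with a slight lean toward a higher number. Compound 4 is therefore estimated at 700 nM, with a range from 300 nM to 1600 nM.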

Compound 4, half-maximal inhibitory concentration: 760 nM
Compound 4: the middle estimate sits 1.1-fold (0.04 log units) below what was measured, and the stated range covers the measured number.
By their numbers in this assay, from the lowest: compounds 3, 1 and 4 (each within the scatter of the next); then compound 2.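

In this assay, among these compounds, putting chloro in place of trifluoromethyl on the aromatic carbon ortho to a chloro group gives a 1.4-fold higher number from compound 3 to compound 4 (0.15 log units; within the scatter) and so supplies the first direct reading of this exchange, in which a single chlorine stands where four heavy atoms stood without a shift that can be told from scatter. Compound 4 also links compound 1 to this series through a second exchange, chloro in place of bromo on an aromatic carbon, which gives a 1.1-fold higher number from compound 1 to compound 4 (0.05 log units; within the scatter) and therefore likewise allows no ordering of the two groups at that carbon, so that compounds 1, 3 and 4 remain one group in this read-out. Nothing measured alongside these numbers accounts for their closeness.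

The compounds shown leave open whether a group of another kind on this aromatic carbon, such as an amine, a methoxy group or a carboxylic acid, would stay within the same range as trifluoromethyl and chloro. They also leave open how the core of compound 2 and its nitrile each bear on the number, since compound 2 differs from the others in more than one place.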